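The source may report more compounds than this note shows. Statements on the series, on what has been measured and on what is new or still open speak of the compounds shown alone.

Measured so far:
compound 1 `CCc1ccc(NC(=S)OCCc2ccccn2)cc1`: 44000 nM
compound 2 `S=C(Nc1ccc(Cl)cc1)OCCc1ccccn1`: 52000 nM

In an ADME assay on MT4 cells (Homo sapiens) for cytotoxicity, read by MTT assay (on this read-out higher numbers stand for lower toxicity in this test and lower numbers for higher toxicity in this test), compound 1 gives 44000 nM, the smaller of the two numbers shown, while compound 2 gives 52000 nM; the step of a 1.2-fold higher number from compound 1 to compound 2 (0.07 log units; within the scatter) is within the scatter. Compound 3 `COc1ccc(NC(=S)OCCc2ccccn2)cc1` has not yet been measured in this assay. It differs from compound 1 in one place: methoxy in place of ethyl on an aromatic carbon. Within the data shown here, the only measured step that bears on such a change at this position is a 1.2-fold higher number from compound 1 to compound 2 (0.07 log units; within the scatter), which stayed within the scatter, so no step beyond the scatter is expected in this assay. Compound 3 is therefore estimated at 48000 nM, with a range from 24000 nM to 96000 nM. The expected step is a 1.1-fold higher number from compound 1 to compound 3 (0.04 log units; within the scatter).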

Compound 3, half-maximal cytotoxic concentration: 48000 nM
The estimate for compound 3 equals the measured number at the digits printed; measured number inside the range.
By their numbers in this assay, from the lowest: compounds 1, 3 and 2 (each within the scatter of the next).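

In this assay, methoxy on this aromatic carbon, para to a large group, gives a number much like those with ethyl and chloro, with a 1.1-fold higher number from compound 1 to compound 3 (0.04 log units; within the scatter) and a 1.1-fold lower number from compound 2 to compound 3 (0.03 log units; within the scatter) as the two steps. Among these compounds, the earlier pair held only groups with no hydrogen-bond acceptor, so this is the first sign that a group counted with one can sit here without a step beyond the scatter. Nothing measured here explains this result. On these data alone, whether an amine, a carboxylic acid or a longer chain at this position would move the number beyond the scatter remains open.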